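The compounds below may be only part of what the source reports. "The series", "measured", "known", "first", "only" and "open" are said of these compounds alone.

Of the compounds shown here, three have so far been tested in a functional assay on the whole organism (strain albino) for inhibition, with Rattus norvegicus as the target, read by paw edema, with a stated time of 2 h, at a dose of 0.28 mmol/kg by the oral route; a lower number here means less inhibition, a higher number more inhibition at the dose given (going by the name of the read-out). All three share a core in which a sulfur-linked side chain carries a phenyl group, while they differ in what sits on the core itself. Compound 1, `O=C(CSc1nnc(-c2ccccc2)n1-c1ccccc1)c1ccccc1`, gives 60%. Compound 2, `COc1ccc(-c2nnc(SCC(=O)c3ccccc3)n2-c2ccccc2)cc1`, gives 57% in this assay. Compound 3, `CCn1c(SC/C(=N/O)c2ccccc2)nnc1-c1ccc(OC)cc1`, gives 72% in this assay, the highest of the three numbers, and its distance from both compound 1 and compound 2 lies beyond the usual scatter of repeated measurements. Compound 4, `CCn1c(SC/C(=N/O)c2ccccc2)nnc1-c1ccccc1`, has not yet been measured in this assay.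

Compound 4 is compound 3 with a single change, (hydrogen in place of methoxy on an aromatic carbon). Exactly the same change, at the same kind of place, turns compound 2 into compound 1, (hydrogen in place of methoxy on an aromatic carbon), and there it gave a number 3 percentage points higher from compound 2 to compound 1 (within the scatter). The cores of compound 2 and compound 3 differ from each other, but that difference is not broken down here, so the change is seen once on each of two cores.

Because the earlier step of a number 3 percentage points higher from compound 2 to compound 1 (within the scatter) stayed within the scatter, the step from compound 3 to compound 4 is expected to be small as well, a number 1 percentage points higher from compound 3 to compound 4 (within the scatter). This rests on one prior example only, and on a different core. Compound 4 is therefore estimated to give about 73% in this assay, expected to fall between 62% and 84%.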

Compound 4, a percentage reported as inhibition, in the whole organism at one dose (the size of the read-out at that dose, not a potency): 69%
Compound 4: middle estimate off by 4 percentage points, on the high side; the range from low to high includes it.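

Replacing methoxy with hydrogen on the second core in this assay gives a number 3 percentage points lower from compound 3 to compound 4 (within the scatter), so going from 4-methoxyphenyl to phenyl again leaves the number within the usual scatter. Set beside the earlier step, the result on one core matches the result on the other, and the opposite signs of the two small steps should not be read as a real difference between the cores: the same change on two cores in this assay, a number 3 percentage points higher (within the scatter) from compound 2 to compound 1 and a number 3 percentage points lower (within the scatter) from compound 3 to compound 4, 6 percentage points apart, within the scatter of two such steps. Across these four compounds, then, this change carries from one core to the other without a step beyond the scatter, but that rests on just two pairs, tested at a single dose and a single time, and it says nothing about potency or about any other core.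

The compounds shown place only methoxy or hydrogen at this spot on the ring, so it remains open whether a different group there, such as an amine, a carboxylic acid or a longer alkoxy chain, would give a step beyond the scatter. The two cores also differ from each other in more than one place, and no pair shown takes those differences one at a time.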